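Aminophenyl swap on the biphenyl pyrazole series

The source may report more compounds than this note shows. Statements on the series, on what has been measured and on what is new or still open speak of the compounds shown alone.

For the measured compounds named here, in a functional assay on NCI-H460 cells (Homo sapiens) for inhibition, read by MTT assay, with a stated time of 48 h (on this read-out higher numbers stand for weaker inhibition of growth and lower numbers for stronger inhibition of growth), compound 2 `COc1cccc(-c2cc(-c3ccccc3-c3ccccc3)n[nH]2)c1` gives 8700 nM, the lowest of the two numbers measured so far; compound 1 `Nc1ccc(-c2cc(-c3ccccc3)n[nH]2)cc1` gives 26700 nM in this assay, a gap beyond the scatter. Compound 3 `Nc1ccc(-c2cc(-c3ccccc3-c3ccccc3)n[nH]2)cc1` is not yet measured. It differs from compound 2 by 4-aminophenyl in place of 3-methoxyphenyl on an aromatic carbon. Going by the values given here, no single step of this kind has been measured, so the expectation rests on compound 1 alone, which also carries 4-aminophenyl and gives 26700 nM. A modest step toward weaker inhibition from compound 2 to compound 3 is expected, a 1.7-fold higher number from compound 2 to compound 3 (0.24 log units; within the scatter), possibly within the scatter. Compound 3 is estimated at 15000 nM, with a range from 5000 nM to 45000 nM.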

Compound 3, concentration for 50% growth inhibition: 8200 nM
The estimate for compound 3 lay 1.8-fold (0.26 log units) above the measured number, within the range that was stated.
By their numbers in this assay, from the lowest: compounds 3 and 2 (each within the scatter of the next); then compound 1.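

In this assay, 4-aminophenyl in place of 3-methoxyphenyl on this aromatic carbon makes no difference beyond the scatter (a 1.1-fold lower number from compound 2 to compound 3 (0.03 log units; within the scatter)), so the position accepts either group, at least in this pair. With 4-aminophenyl kept, phenyl in place of hydrogen does give a step beyond the scatter (a 3.3-fold lower number from compound 1 to compound 3 (0.51 log units; beyond the scatter)), so that change, not the swap, separates these numbers. No supporting measurement bears on why either step has its size.

Still open, as far as these compounds go, is whether a hydroxyl or a carboxylic acid on this phenyl ring, in place of the amine, keeps the number. The same question applies to a longer chain on that nitrogen.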